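Ethoxy in place of chloro: compound 2 to compound 4

A few compounds are considered here, and "the series" means these few. Any claim that something is new, unique, unknown or untested is made for them only; others in the source may bear on it.

Compound 1 `COc1ccc(-c2ncnn2-c2cc(OC)c(OC)c(OC)c2)cc1`: 520 nM
Compound 2 `COc1cc(-n2ncnc2-c2ccc(Cl)cc2)cc(OC)c1OC`: > 10000 nM (a limit)
Compound 3 `COc1cc(-n2ncnc2-c2ccc(Cl)c(Cl)c2)cc(OC)c1OC`: > 10000 nM (a limit)

In a functional assay on A549 cells (Homo sapiens) for antiproliferative activity, read by MTT assay, with a stated time of 72 h (a lower number here means a stronger inhibitor, a higher number a weaker inhibitor), compound 2 gives only a limit, > 10000 nM. This is the limit of > 10000 nM in this assay, at which 2 of the 3 values shown sit, and compound 3 supplies the other such value.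

Compound 4 `CCOc1ccc(-c2ncnn2-c2cc(OC)c(OC)c(OC)c2)cc1` is reached from compound 2 by the change ethoxy in place of chloro on an aromatic carbon, para to a large group.

The closest measured evidence is an at least 19-fold higher number from compound 1 to compound 2 (1.28 log units; beyond the scatter), a swap between methoxy and chloro at this place. Also large is an at least 19-fold higher number from compound 1 to compound 3 (1.28 log units; beyond the scatter). No size can be taken from a step that the two limits leave unreadable from compound 2 to compound 3. Ethoxy itself is unmeasured here, and the expectation rests on compound 1 alone.

Going by compound 1 at 520 nM, a large step to a lower number is expected in this assay. The expected change is an at least 14-fold lower number from compound 2 to compound 4 (1.15 log units; beyond the scatter). The estimate for compound 4 is 700 nM, with an expected range of 120 nM to 5000 nM.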

Compound 4, half-maximal inhibitory concentration: 100 nM
Compound 4: the middle estimate sits 7.0-fold (0.85 log units) above what was measured, and the stated range ends above it.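

In this assay, one added methyl on the chain at this place, para to a large group, gives a 5.2-fold lower number from compound 1 to compound 4 (0.72 log units; beyond the scatter), so activity at this position does not peak at methoxy. Ethoxy in place of chloro gives an at least 100-fold lower number from compound 2 to compound 4 (2.00 log units; beyond the scatter), a larger gap than the swap between methoxy and chloro had shown. Compound 2 carries a limit and not a number, so that step has only one firm end: the limit of > 10000 nM in this assay, at which 2 of the 4 values shown sit.

Going by these compounds, whether the gain continues along a longer chain such as propoxy or butoxy, or survives branching as in isopropoxy, stays open. Also open, on these data alone, is whether the ring oxygen or the chain carries the gain, a question a plain ethyl or propyl group at this place would help to settle.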